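From Isopropyl to (Methylcarbamoyl)methyl on an Aromatic Nitrogen

The source may report more compounds than this note shows. Statements on the series, on what has been measured and on what is new or still open speak of the compounds shown alone.

Of the compounds shown here, three sharing one core have been measured in a physicochemical assay for solubility, read by chemiluminescence, measured as kinetic solubility; a higher number here means a more soluble compound, a lower number a less soluble compound. Compound 1 `COc1nn(C)c2ncnc(NS(=O)(=O)c3cccc(Cl)c3Cl)c12` gives >= 581000 nM, which is a limit of the assay. Compound 2 `COCCOc1nn(C)c2ncnc(NS(=O)(=O)c3cccc(Cl)c3Cl)c12` gives >= 463000 nM, which is also a limit. Compound 3 `COc1nn(C(C)C)c2ncnc(NS(=O)(=O)c3cccc(Cl)c3Cl)c12` gives 404000 nM, the only one of the three results that is an actual number.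

Compound 4 `CNC(=O)Cn1nc(OC)c2c(NS(=O)(=O)c3cccc(Cl)c3Cl)ncnc21` has not yet been measured. It differs from compound 3 by (methylcarbamoyl)methyl in place of isopropyl on an aromatic nitrogen.

Within the data shown here, only one measured step changes the group on that aromatic nitrogen: an at least 1.4-fold lower number from compound 1 to compound 3 (0.15 log units; that floor lies within the scatter). Its size is known only as a floor, so it gives weak guidance. The other measured step, a step that the two limits leave unreadable from compound 1 to compound 2, involves a chain on an oxygen instead and has no readable size. Neither offers a measured precedent for the group entering compound 4, so no clear direction can be assigned.

In this assay, the expected result is a 1.1-fold higher number from compound 3 to compound 4 (0.03 log units; within the scatter), an estimated change that stays within the scatter. The estimate for compound 4 is 430000 nM, with an expected range of 250000 nM to 600000 nM.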

Compound 4, solubility: >= 509000 nM
Compound 4: a limit, no number; the forecaster's own chance of this, stated with the estimate: 50%; at least 1.1-fold (0.07 log units) between middle value and limit.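

In this assay, among these compounds, compound 4 joins compound 1 and compound 2 in ending at a limit of the assay rather than a number, which leaves compound 3 as the only compound with an actual number: the limit of >= 509000 nM in this assay, at which 1 of the 4 values shown sits. On these data alone, the change on the aromatic nitrogen gives an at least 1.2-fold higher number from compound 3 to compound 4 (0.10 log units; that floor lies within the scatter), so the true size is unknown and the known floor does not clear the usual scatter. Even so, the result shows that this nitrogen can carry (methylcarbamoyl)methyl, with its hydrogen-bond donor and hydrogen-bond acceptor where isopropyl has none, without any drop from compound 3 in this read-out, whereas the steps that join two limits, including the one from compound 1 to compound 4, cannot be read.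

The compounds shown leave open how far the true value of compound 4 lies from its limit, and so how large this change really is. They also leave open whether a dimethyl amide without the amide hydrogen, a carboxylic acid, an amine or a longer chain on this nitrogen would give a readable number in this assay.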